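The source may hold more compounds than are shown below. What is called first, only, known or untested is meant among the compounds shown, and "the series" means these compounds.

Measured compounds:
compound 1 `N#CC1=C(N)Oc2c(N)cc3nc4ccccc4nc3c2C12C(=O)N(Cc1cnnn1-c1ccc(F)cc1)c1ccccc12`: in a functional assay on MCF7 cells (Homo sapiens) for antiproliferative activity, read by MTT assay, with a stated time of 48 h (a higher number here means a weaker inhibitor, a lower number a stronger inhibitor), compound 1 gives > 50000 nM, a limit of the assay.
compound 2 `N#CC1=C(N)Oc2c(N)cc3nc4ccccc4nc3c2C12C(=O)N(Cc1cnnn1-c1ccccc1Cl)c1ccccc12`: in this assay compound 2 gives 34400 nM.
compound 3 `N#CC1=C(N)Oc2c(N)cc3nc4ccccc4nc3c2C12C(=O)N(Cc1cnnn1-c1c(F)cccc1F)c1ccccc12`: in this assay compound 3 gives > 50000 nM, a limit of the assay.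

Compound 3 sits at the limit of > 50000 nM in this assay, at which 2 of the 3 values shown sit; its value is a limit, not a number, so it cannot be placed against compound 1 beyond saying both are limits. Against compound 2 the step of an at least 1.4-fold higher number from compound 2 to compound 3 (0.16 log units; that floor lies within the scatter) is readable only as a floor.

Compound 4 `N#CC1=C(N)Oc2c(N)cc3nc4ccccc4nc3c2C12C(=O)N(Cc1cnnn1-c1ccc(Cl)cc1Cl)c1ccccc12` is not yet measured. It differs from compound 3 by 2,4-dichlorophenyl in place of 2,6-difluorophenyl on an aromatic nitrogen. Within the data shown here, the steps that bear on this aryl substituent are an at least 1.4-fold lower number from compound 1 to compound 2 (0.16 log units; that floor lies within the scatter) and an at least 1.4-fold higher number from compound 2 to compound 3 (0.16 log units; that floor lies within the scatter); the step that the two limits leave unreadable from compound 1 to compound 3 is not readable. Among the measured compounds shown here, all three measured compounds sit near or at the limit, and the only number among them, compound 2, is itself weak. The new group carries chlorine as compound 2 does, so compound 4 is expected to land near compound 2 or at the limit, with no step beyond the scatter, the expected step being an at least 1.2-fold lower number from compound 3 to compound 4 (0.09 log units; that floor lies within the scatter). For compound 4 the estimate in this assay is 40000 nM, expected to lie between 15000 nM and 150000 nM.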

Compound 4, half-maximal inhibitory concentration: > 50000 nM
Compound 4: only a limit was reported (the forecaster's own chance of this, stated with the estimate: 55%); middle value at least 1.2-fold (0.09 log units) away from the limit.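

In this assay, chloro in place of hydrogen on an aromatic carbon of the aryl group gives an at least 1.4-fold higher number from compound 2 to compound 4 (0.16 log units; that floor lies within the scatter). That floor lies within the scatter, so the second chlorine shows no change that can be told apart, yet compound 4 is a limit of the assay where compound 2 gave a number. Carrying chlorine on this aryl group is therefore not enough to give a measured value, as compound 4 goes against any such pattern, and the series now stands largely at one limit: the limit of > 50000 nM in this assay, at which 3 of the 4 values shown sit.

Going by these compounds, the steps to compound 4 from compound 1 and from compound 3 join two limits and cannot be read, so any order among compound 1, compound 3 and compound 4 stays open. Also open, on these data alone, is whether an amine or a carboxylic acid on this aryl group, in place of the halogens seen so far, would bring a value clear of the limit.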